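The source may report more compounds than this note shows. Statements on the series, on what has been measured and on what is new or still open speak of the compounds shown alone.

Series of three measured compounds and one unmeasured. Compound 1 `Oc1cccc(-c2cc(-c3ccccc3)nc(-c3ccccc3Cl)c2)c1` gives 3.2% in an assay on isolated protein for inhibition of DNA topoisomerase 1 (Homo sapiens), with a stated time of 30 min, tested at 100 uM; a lower number here means a weaker effect, a higher number a stronger effect of the compound at the concentration tested. Compound 3 `Oc1ccc(-c2cc(-c3ccccc3)nc(-c3cccc(Cl)c3)c2)cc1` gives 0% in this assay; the two values lie within the scatter of each other, and the difference between the two cores is not broken down here. Compound 2 `Oc1ccc(-c2cc(-c3ccsc3)nc(-c3cccc(Cl)c3)c2)cc1` gives 26%; the step from compound 3 to it is thiophen-3-yl in place of phenyl on an aromatic carbon, with a number 26 percentage points higher from compound 3 to compound 2 (beyond the scatter).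

Compound 4 `Oc1cccc(-c2cc(-c3ccsc3)nc(-c3ccccc3Cl)c2)c1` is not yet measured. It differs from compound 1 by thiophen-3-yl in place of phenyl on an aromatic carbon. The place lines differ around the position: in compound 1 the carbon bearing the change is meta to a 2-chlorophenyl group and meta to a 3-hydroxyphenyl group, whereas in compound 3 it is meta to a 3-chlorophenyl group and meta to a 4-hydroxyphenyl group. The change is thus the same kind of change, not the same.

For the measured compounds named here, the expectation for compound 4 in this assay is a step of a number 19.8 percentage points higher from compound 1 to compound 4 (beyond the scatter), somewhat smaller than the one measured from compound 3 to compound 2, because only that single step a number 26 percentage points higher from compound 3 to compound 2 (beyond the scatter) supports it and the surroundings differ. Compound 4 is estimated at 23%, between 5% and 45%.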

Compound 4, a percentage reported as inhibition, at one concentration (the size of the read-out at that concentration, not a potency): 0%
The estimate for compound 4 lay 23 percentage points above the measured number; measured number below the stated range.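

In this assay, thiophen-3-yl in place of phenyl on an aromatic carbon comes out here as a number 3.2 percentage points lower from compound 1 to compound 4 (within the scatter). The rise seen on the core of compound 3 therefore does not carry over to the core of compound 1, and in this series the outcome of the change depends on the core that bears it: the same change on two cores in this assay, a number 26 percentage points higher (beyond the scatter) from compound 3 to compound 2 and a number 3.2 percentage points lower (within the scatter) from compound 1 to compound 4, 29.2 percentage points apart, beyond the scatter of two such steps What this does not show is which difference between the two cores matters, the 2-chlorophenyl against the 3-chlorophenyl group or the 3-hydroxyphenyl against the 4-hydroxyphenyl group, as the two differ together in these compounds and are not separated.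

The compounds shown leave open how a core with only one of these differences responds to the same change. They also leave open what an amine or a carboxylic acid in place of the hydroxyl group, or a longer chain in place of thiophen-3-yl, would do at a single tested concentration in this assay.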